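Removing the acetyl from the ring nitrogen of compound 3

This account rests on a few compounds, and the source may have more. Where it says the series, first, only, none or still open, it means among the compounds named here.

Measured so far in a functional assay on HepG2 cells (Homo sapiens) for cytotoxicity, read by MTT assay, with a stated time of 72 h; on this read-out higher numbers stand for weaker inhibition and lower numbers for stronger inhibition:
compound 1 `COc1ccc2ccc(=O)oc2c1C1=NN(C(C)=O)C(c2ccc(SC)cc2)C1` gives 42 nM
compound 2 `COc1ccc2ccc(=O)oc2c1C1=NN(C(N)=O)C(c2ccc(C(F)(F)F)cc2)C1` gives 96 nM
compound 3 `COc1ccc2ccc(=O)oc2c1C1=NN(C(C)=O)C(c2ccc(C(F)(F)F)cc2)C1` gives 80 nM

Compound 3 stands second highest of the three numbers. Its nearest neighbour is compound 2 and the step of a 1.2-fold lower number from compound 2 to compound 3 (0.08 log units; within the scatter) is within the scatter; its furthest is compound 1 and the step of a 1.9-fold higher number from compound 1 to compound 3 (0.28 log units; within the scatter) is also within the scatter. All three numbers therefore sit together with no separation beyond the scatter.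

Compound 4 `COc1ccc2ccc(=O)oc2c1C1=NNC(c2ccc(C(F)(F)F)cc2)C1` differs from compound 3 by hydrogen in place of acetyl on an amine nitrogen in a ring. For the measured compounds named here, no measured step touches this position: the two steps recorded concern the aromatic substituent and the group on the carbonyl carbon, and both left the number within the scatter. They do not tell what removing the acetyl altogether does. Without a bearing step, the expectation is simply anchored on compound 3 with a wide range, leaning to a somewhat higher number.

For compound 4 in this assay the estimate is 150 nM with a range of 50 nM to 500 nM. The step this estimate implies is expected to be a 1.9-fold higher number from compound 3 to compound 4 (0.27 log units; within the scatter).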

Compound 4, half-maximal inhibitory concentration: 13 nM
Compound 4: middle estimate off by 12-fold (1.06 log units), on the high side; the measured number lies below the stated range.
By their numbers in this assay, from the lowest: compound 4; then compounds 1, 3 and 2 (each within the scatter of the next, the first and the last beyond it).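

In this assay, the amine nitrogen in the ring is the only position among those shown where a single change moves the number beyond the scatter: hydrogen in place of acetyl gives a 6.2-fold lower number from compound 3 to compound 4 (0.79 log units; beyond the scatter) as the step. Hydrogen in place of carbamoyl points the same way, with a 7.4-fold lower number from compound 2 to compound 4 (0.87 log units; beyond the scatter) as the step, whereas exchanging carbamoyl for acetyl on that nitrogen stays within the scatter, at a 1.2-fold lower number from compound 2 to compound 3 (0.08 log units; within the scatter) as the step. Nothing at hand gives a reason for the drop on removing either group.

Open, from the compounds shown here alone, is whether a methyl or a longer acyl chain such as propanoyl on this nitrogen stays near compound 4 or returns towards compound 3. Also open, going by these compounds, is whether methylsulfanyl in place of trifluoromethyl on the aromatic ring changes the number when hydrogen sits on this nitrogen.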